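The compounds below may be only part of what the source reports. "The series", "measured", "known", "first", "only" and "open" are said of these compounds alone.

In a functional assay on MDA-MB-231 cells (Homo sapiens) for inhibition, read by MTT assay, with a stated time of 72 h (a higher number here means a weaker inhibitor, a lower number a stronger inhibitor), compound 2 (`CC(C)[C@H](NC(=O)c1cc(Cl)ccc1OCCNC(=O)OCc1ccccc1)C(=O)Nc1ccc([N+](=O)[O-])cc1Cl`) reads > 10000 nM and this is a limit of the assay, not a number. That places compound 2 at the limit of > 10000 nM in this assay, at which 1 of the 2 values shown sits, with no exact value known. Compound 1 (`CC(C)COC(=O)NCCOc1ccc(Cl)cc1C(=O)N[C@H](C(=O)Nc1ccc([N+](=O)[O-])cc1Cl)C(C)C`) gives 4900 nM in the same test. Going by the values given here, the one measured step, phenyl in place of isopropyl, is an at least 2.0-fold higher number from compound 1 to compound 2 (0.30 log units; that floor lies within the scatter) and so offers only weak guidance. Compound 3 (`CC(C)[C@H](NC(=O)c1cc(Cl)ccc1OCCCN)C(=O)Nc1ccc([N+](=O)[O-])cc1Cl`) brings a larger change, aminomethyl in place of (benzyloxycarbonyl)amino on a saturated chain carbon, two bonds along the chain from an oxygen on an aromatic ring with aminomethyl in place of (benzyloxycarbonyl)amino on a saturated chain carbon, two bonds along the chain from an oxygen on an aromatic ring. With the phenyl gone from compound 3, and resting on an at least 2.0-fold higher number from compound 1 to compound 2 (0.30 log units; that floor lies within the scatter) alone, a lower number of uncertain size is expected in this assay here. The expected change is an at least 1.4-fold lower number from compound 2 to compound 3 (0.15 log units; that floor lies within the scatter) for now. The estimated value for compound 3 is 7000 nM within a range of 2500 nM to 20000 nM and a reading at the limit remains possible.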

Compound 3, half-maximal inhibitory concentration: 6770 nM
Beside the measured number, compound 3's estimate is 1.0-fold (0.01 log units) above it; measured number inside the range.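

Compound 2 holds only a limit of the assay and not a number: the limit of > 10000 nM in this assay, at which 1 of the 3 values shown sits.

In this assay the swap of (benzyloxycarbonyl)amino for aminomethyl at this position gives an at least 1.4-fold lower number from compound 2 to compound 3 (0.16 log units; that floor lies within the scatter) and so has only a floor, which by itself does not establish a real gain. The firmer reading comes from two exact values, a 1.4-fold higher number from compound 1 to compound 3 (0.14 log units; within the scatter), which shows that in this one pair aminomethyl can take the place of (isobutoxycarbonyl)amino with no change beyond the scatter.

The compounds shown leave open whether any group at this place can bring the number clearly under that of compound 1. A carboxylic acid or a longer chain ending in an amine, on the same saturated chain carbon, would test how far this position responds.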